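Replacing a Five-Atom Group by Amino: Growth Inhibition Compared

The source may report more compounds than this note shows. Statements on the series, on what has been measured and on what is new or still open speak of the compounds shown alone.

Measured compounds: compound 1 `Cc1ccc(-c2cc(N)n(-c3ccc(Br)cc3)n2)cc1`; compound 2 `Cc1ccc(-c2nn(-c3cccc(Cl)c3)c(/N=C/N(C)C)c2C=O)cc1`; compound 3 `Cc1ccc(-c2cc(/N=C/N(C)C)n(-c3ccc(Br)cc3)n2)cc1`.

In a functional assay on Jurkat cells (Homo sapiens) for inhibition, read by MTT assay, with a stated time of 72 h (a higher number here means a weaker inhibitor of growth, a lower number a stronger inhibitor of growth), compound 1 gives 45000 nM. Compound 2 gives 7800 nM. For compound 3 only a limit is recorded, > 100000 nM. That reading is the limit of > 100000 nM in this assay, at which 1 of the 3 values shown sits.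

Compound 3 and compound 1 differ by one nitrogen atom in place of a group of 5 heavy atoms (3 carbon, 2 nitrogen; no ring), on an aromatic carbon. The measured step is an at least 2.2-fold lower number from compound 3 to compound 1 (0.34 log units; beyond the scatter).

Compound 4 `Cc1ccc(-c2nn(-c3cccc(Cl)c3)c(N)c2C=O)cc1` has not been measured. It differs from compound 2 by one nitrogen atom in place of a group of 5 heavy atoms (3 carbon, 2 nitrogen; no ring), on an aromatic carbon, the same kind of change, though here the place is next to the ring atom that bears a 3-chlorophenyl group and next to the ring atom that bears a formyl group, whereas in compound 1 it is next to the ring atom that bears a 4-bromophenyl group. How the core of compound 2 differs from that of compound 3 is not broken down here.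

Because an at least 2.2-fold lower number from compound 3 to compound 1 (0.34 log units; beyond the scatter) was seen, compound 4 is expected to show a similar step, a 2.2-fold lower number from compound 2 to compound 4 (0.35 log units; beyond the scatter). Compound 4 is therefore estimated at 3500 nM, between 1000 nM and 12000 nM.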

Compound 4, concentration for 50% growth inhibition: 86300 nM
Compound 4: the middle estimate sits 25-fold (1.39 log units) below what was measured; measured number outside the range, above it.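

In this assay, the exchange for amino gives an 11-fold higher number from compound 2 to compound 4 (1.04 log units; beyond the scatter), so the change did not carry over in direction from the other core: the same change on two cores in this assay, an at least 2.2-fold lower number (0.34 log units; beyond the scatter) from compound 3 to compound 1 and an 11-fold higher number (1.04 log units; beyond the scatter) from compound 2 to compound 4, at least 24-fold (1.39 log units) apart, beyond the scatter of two such steps

Compound 3 is recorded only as a limit: the limit of > 100000 nM in this assay, at which 1 of the 4 values shown sits.

These two pairs show that the step depends on the core in this series, but not which difference between the cores decides its direction, whether the formyl group, the 3-chlorophenyl group or the 4-bromophenyl group.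

The compounds shown leave open how amino and the five-atom group compare on a core carrying both the formyl group and the 4-bromophenyl group. Also open, on these data alone, is whether a nitrile or a carboxylic acid in place of the formyl group would give the same reversal.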